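Notes on replacing the octyl group of compound 1

The source may report more compounds than this note shows. Statements on the series, on what has been measured and on what is new or still open speak of the compounds shown alone.

Measured so far in a physicochemical assay for lipophilicity, in phosphate buffer, measured as octanol-water partition, at pH 11.5; a higher number here means a more lipophilic compound, a lower number a more polar compound
- compound 1 `CCCCCCCCCCOC(=N)NC(=N)Nc1ccc(Cl)cc1` gives 6.32
- compound 2 `CCSc1ccc(NC(=N)NC(=N)NCCCCCCNC(=N)NC(=N)Nc2ccc(SCC)cc2)cc1` gives 5.58
- compound 3 `CCCCCS(=O)(=O)c1ccc(NC(=N)NC(=N)NCCCCCCNC(=N)NC(=N)Nc2ccc(S(=O)(=O)CCCCC)cc2)cc1` gives 4.1

Compound 1 holds the highest of the three numbers. Compound 2 lies nearest to it and compound 3 furthest from it, and both gaps are beyond the scatter. For the measured compounds named here, compound 2 and compound 3 differ from compound 1 in more than one place, and no pair of measured compounds differs in only one. Going by the values given here, no measured step therefore bears directly on the next comparison.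

The next compound is compound 4 `CCOC(=N)NC(=N)Nc1ccc(Cl)cc1`, which shares the core of compound 1. The change is hydrogen in place of octyl on a saturated chain carbon, two bonds along the chain from an oxygen on an unsaturated carbon, with hydrogen in place of octyl on a saturated chain carbon, two bonds along the chain from an oxygen on an unsaturated carbon.

A large downward step in this assay, well beyond the scatter, is expected. This expectation rests on the size of the group that leaves and on the starting point of compound 1 at 6.32, and it remains a judgement without a measured step behind it. The estimated change is a number 3.92 log units lower from compound 1 to compound 4 (beyond the scatter). For compound 4 the estimated value is 2.4, with an expected range from 1.8 to 3.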

Compound 4, partition coefficient: 2.32
Estimate against measurement, compound 4: 0.08 log units above, within the range that was stated.
By their numbers in this assay, from the lowest: compound 4; then compound 3; then compound 2; then compound 1.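

In this assay, for the compounds shown here, the exchange of octyl for hydrogen on a saturated chain carbon, two bonds along the chain from an oxygen on an unsaturated carbon, gives a number 4.00 log units lower from compound 1 to compound 4 (beyond the scatter) and is the first step that can be read at a single place. The earlier compounds shown here differed from compound 1 in more than one place, so they could not tie any part of a gap to this position, whereas this pair, which shares the core of compound 1, shows that this position alone can carry a large change in the read-out. No supporting measurement accompanies this step, so the data give no account of what lies behind its size.

The pair fixes only two points at this position, octyl and hydrogen, and so leaves open how the number runs for a chain of intermediate length, such as butyl, and whether the change follows chain length in a steady way. Also open, going by these compounds, is how a branched chain such as isopropyl, a phenyl ring, or a chain ending in an amine or a hydroxyl group would read at this position.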